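The source may report more compounds than this note shows. Statements on the series, on what has been measured and on what is new or still open speak of the compounds shown alone.

Compound 2 `COc1cc2ncnc(Nc3ccc(F)cc3)c2cc1OCCCCC(=O)Nc1ccc(S(N)(=O)=O)cc1` gives 18600 nM in a functional assay on A-431 cells (Homo sapiens) for antiproliferative activity, read by MTT assay, with a stated time of 72 h (a lower number here means a stronger inhibitor, a higher number a weaker inhibitor), the larger of the two numbers shown, while compound 1 `COc1cc2ncnc(Nc3cccc(Br)c3)c2cc1OCCCCC(=O)Nc1ccc(S(N)(=O)=O)cc1` gives 9750 nM; the step of a 1.9-fold higher number from compound 1 to compound 2 (0.28 log units; within the scatter) lies within the scatter. Compound 3 `COc1cc2ncnc(Nc3ccc(Br)cc3)c2cc1OCCCCC(=O)Nc1ccc(S(N)(=O)=O)cc1` differs from compound 2 by bromo in place of fluoro on an aromatic carbon. No measured step swaps these two halogens at one and the same place, and the only step shown, which alters halogen and place together, stays within the scatter, so no step beyond the scatter is expected in this assay. Compound 3 is therefore expected at 12000 nM, within 5000 nM to 30000 nM, a step of a 1.6-fold lower number from compound 2 to compound 3 (0.19 log units; within the scatter).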

Compound 3, half-maximal inhibitory concentration: 6570 nM
The estimate for compound 3 lay 1.8-fold (0.26 log units) above the measured number, within the range that was stated.
By their numbers in this assay, from the lowest: compounds 3, 1 and 2 (each within the scatter of the next, the first and the last beyond it).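

In this assay, within the data shown here, fluoro to bromo on an aromatic carbon para to a large group gives the first step beyond the scatter (a 2.8-fold lower number from compound 2 to compound 3 (0.45 log units; beyond the scatter)), so the identity of the halogen at this position registers, though only modestly. Moving the bromine makes no readable difference, as 4-bromophenyl in place of 3-bromophenyl stays within the scatter (a 1.5-fold lower number from compound 1 to compound 3 (0.17 log units; within the scatter)). No measurement is at hand that accounts for the halogen step.

On these data alone, whether chloro at this position would read with fluoro or with bromo remains open. So does whether an amine there, or a longer chain on the shared core, would shift the number further.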